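A few compounds are considered here, and "the series" means these few. Any claim that something is new, unique, unknown or untested is made for them only; others in the source may bear on it.

Measured so far:
- Compound 1, `NCC(O)CNc1cc(N2CCCc3ccccc3C2)nc2ccccc12`: 21000 nM
- Compound 2, `NCCNc1cc(N2CCCc3ccccc3C2)nc2ccc(Cl)cc12`: > 3200 nM
- Compound 3, `Cc1ccc2nc(N3CCCc4ccc(F)cc4C3)cc(NCCN(C)C)c2c1`: 89000 nM

In an ADME assay on HEp-2 cells (Homo sapiens) for cytotoxicity, read by CCK-8 assay, with a stated time of 5 days (a higher number here means that more compound is tolerated, a lower number that less compound is tolerated), compound 3 gives the highest of the two numbers shown; the nearest is compound 1, whose value is lower by a margin beyond the usual scatter. For compound 2 the entry is only a limit of the assay, not a measured number; it is the limit of > 3200 nM in this assay, at which 1 of the 3 values shown sits.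

Compound 4, `Cc1ccc2nc(N3CCCc4ccc(F)cc4C3)cc(NCC(N)=O)c2c1`, has not yet been measured in this assay. It differs from compound 3 in one place: carbamoyl in place of (dimethylamino)methyl on a saturated chain carbon bound to a nitrogen on an aromatic ring. Going by the values given here, no pair of measured compounds shows a step of this kind, so no measured comparison exists to lean on.

Given that, the expectation for compound 4 is a modest step, in the upward direction if any, since compound 3 already stands at 89000 nM. Compound 4 is estimated at 120000 nM, in the range 40000 nM to 350000 nM. The step this implies, a 1.3-fold higher number from compound 3 to compound 4 (0.13 log units; within the scatter), is expected to stay close to the scatter of repeated measurements.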

Compound 4, half-maximal cytotoxic concentration: 22000 nM
The estimate for compound 4 lay 5.5-fold (0.74 log units) above the measured number; the whole stated range lies above it.
By their numbers in this assay, from the lowest: compounds 1 and 4 (each within the scatter of the next); then compound 3.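

In this assay, going by these compounds alone, the first single-place change in this set shows that this position is not indifferent to what it carries: carbamoyl in place of (dimethylamino)methyl gives a 4.0-fold lower number from compound 3 to compound 4 (0.61 log units; beyond the scatter). The cells therefore tolerate less of the compound once the chain ends in carbamoyl, and the shift is larger than repeat measurements would normally produce. Nothing measured here explains this drop.

This single step cannot separate the effect of losing the dimethylamino end from that of gaining the carbamoyl. A plain primary amine or a carboxylic acid on the same chain, or a longer chain carrying the carbamoyl, would show whether tolerance follows the end group, the chain length or both.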